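Notes on an oxygen-linked analogue of compound 3

This account rests on a few compounds, and the source may have more. Where it says the series, first, only, none or still open, it means among the compounds named here.

The three measured compounds share one core and are characterised in an in vitro assay on CHOK cells for displacement of a labelled ligand from growth hormone secretagogue receptor type 1 (Homo sapiens); a lower number here means a stronger inhibitor, a higher number a weaker inhibitor. Compound 1 `CCc1nc(N)nc(N)c1-c1ccc(NCc2ccnc(Cl)c2)cc1` gives 110 nM; compound 2 `Nc1nc(N)c(-c2ccc(NCc3cc(F)c(S(=O)(=O)C(F)(F)F)c(F)c3)cc2)c(COCc2ccccc2)n1` gives 1 nM; compound 3 `Nc1nc(N)c(-c2ccc(NCc3ccnc(Cl)c3)cc2)c(COCc2ccccc2)n1` gives 1.5 nM. Compound 3 thus holds the second highest of the three numbers, with compound 2 within the scatter of it and compound 1 far beyond the scatter. For the measured compounds named here, the only single-point step measured is a 73-fold lower number from compound 1 to compound 3 (1.87 log units; beyond the scatter), which concerns the saturated chain carbon on the core and not the arm now varied. Compound 4 `N#Cc1ccc(COc2ccc(-c3c(N)nc(N)nc3COCc3ccccc3)cc2)cc1` carries (4-cyanobenzyl)oxy in place of ((2-chloropyridin-4-yl)methyl)amino on an aromatic carbon. Going by the values given here, no measured step bears directly on this change: compounds 2 and 3 show only that the aromatic ring on that arm can be exchanged with the two values staying within the scatter of each other, whereas replacement of the nitrogen-linked arm by an oxygen-linked one, with its hydrogen-bond donor gone, is untested in this set. A modest weakening is allowed for the untested linker while the rest of the structure is kept, so compound 4 is estimated at 5 nM (range 1 nM to 30 nM). The expected step is a 3.3-fold higher number from compound 3 to compound 4 (0.52 log units; beyond the scatter).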

Compound 4, half-maximal inhibitory concentration: 83 nM
Estimate against measurement, compound 4: 17-fold (1.22 log units) below, outside the stated range (above it).
By their numbers in this assay, from the lowest: compounds 2 and 3 (each within the scatter of the next); then compounds 4 and 1 (each within the scatter of the next).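

In this assay, putting (4-cyanobenzyl)oxy in place of ((2-chloropyridin-4-yl)methyl)amino gives a large loss (a 55-fold higher number from compound 3 to compound 4 (1.74 log units; beyond the scatter)), so what stands at this position, on an aromatic carbon para to a large group, can matter strongly to the number. For the compounds shown here, the earlier pair, compound 2 (1 nM) and compound 3 (1.5 nM), lie within the scatter of each other and show only that the ring can be exchanged while the nitrogen link is kept; the new step shows that this tolerance does not carry over to a change in which the linking atom, the ring and its substituent all differ, with one hydrogen-bond donor fewer in the entering arm. No measurement in hand accounts for the size of this step.

Which part of the exchange carries the loss stays open, as the oxygen link, the carbon-only ring and the nitrile all enter together in compound 4. A (4-cyanobenzyl)amino arm or a ((2-chloropyridin-4-yl)methyl)oxy arm on the same core would separate the linking atom from the ring.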